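The source may report more compounds than this note shows. Statements on the series, on what has been measured and on what is new or still open speak of the compounds shown alone.

Compound 1 `CCCSc1nc2nc(C)cc(N3CC[C@@H](C)[C@@H](N(C)c4ncnc5[nH]ccc45)C3)n2n1` is the starting point of this step. In a functional assay on HGC-27 cells (Homo sapiens) for inhibition, read by MTT assay, with a stated time of 72 h (on this read-out lower numbers stand for stronger inhibition and higher numbers for weaker inhibition), compound 1 gives 20900 nM, the highest of the three numbers, though only by margins within the scatter. Compound 2 `Cc1cc(N2CC[C@@H](C)[C@@H](N(C)c3ncnc4[nH]ccc34)C2)n2nc(SCc3ccc(Cl)cc3)nc2n1` gives 18400 nM and compound 3 `COc1ccc(CSc2nc3nc(C)cc(N4CC[C@@H](C)[C@@H](N(C)c5ncnc6[nH]ccc56)C4)n3n2)cc1` gives 18200 nM. Compound 4 `Cc1cc(N2CC[C@@H](C)[C@@H](N(C)c3ncnc4[nH]ccc34)C2)n2nc(SCc3csc4ccc(Cl)cc34)nc2n1` differs from compound 1 by 5-chloro-1-benzothiophen-3-yl in place of ethyl on a saturated chain carbon bound to a sulfur. Going by the values given here, the steps that bear on it are those at the same place: a 1.1-fold lower number from compound 1 to compound 2 (0.06 log units; within the scatter) and a 1.1-fold lower number from compound 1 to compound 3 (0.06 log units; within the scatter), both within the scatter, and likewise a 1.0-fold lower number from compound 2 to compound 3 (0.00 log units; within the scatter). Since neither aryl replacement at this position shifted the number, no step beyond the scatter is expected here either, and compound 4 is estimated at 17000 nM, between 8000 nM and 40000 nM, meaning an expected 1.2-fold lower number from compound 1 to compound 4 (0.09 log units; within the scatter).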

Compound 4, half-maximal inhibitory concentration: > 100000 nM
Compound 4 ended at the assay's limit; the forecaster's own chance of this, stated with the estimate: 5%; at least 5.8-fold (0.76 log units) between middle value and limit.
By their numbers in this assay, from the lowest: compounds 3, 2 and 1 (each within the scatter of the next). At a limit, above all of these: compound 4.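

In this assay, the saturated chain carbon bound to a sulfur proves sensitive to what it carries: 5-chloro-1-benzothiophen-3-yl gives an at least 4.7-fold higher number from compound 1 to compound 4 (0.67 log units; beyond the scatter), although 4-chlorophenyl and 4-methoxyphenyl had stayed within the scatter of ethyl. The same change gives an at least 5.4-fold higher number from compound 2 to compound 4 (0.73 log units; beyond the scatter) and an at least 5.4-fold higher number from compound 3 to compound 4 (0.73 log units; beyond the scatter), so the two aryl compounds also stand apart from compound 4. The result for compound 4 is a limit of the assay, not a number: the limit of > 100000 nM in this assay, at which 1 of the 4 values shown sits.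

The compounds shown leave open whether an unsubstituted 1-benzothiophen-3-yl or a naphthyl group would behave like 5-chloro-1-benzothiophen-3-yl. They also leave open how large the true step to compound 4 is.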